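The compounds below may be only part of what the source reports. "The series", "measured", "known", "first", "only" and "open" are said of these compounds alone.

Compounds measured in an ADME assay on L1210 cells (Mus musculus) for cytotoxicity, with a stated time of 48 h; on this read-out lower numbers stand for stronger inhibition and higher numbers for weaker inhibition:
compound 1 `C=C1[C@H](C)CCC[C@]1(C)CC/C(C)=C/CC1=C(O)C(=O)C=C(N[C@@H](C(=O)O)[C@H](C)O)C1=O` gives 4.6 ug/mL;
compound 2 `C=C1[C@H](C)CCC[C@]1(C)CC/C(C)=C/CC1=C(O)C(=O)C=C(N[C@H](C(=O)O)[C@H](C)O)C1=O` gives > 10 ug/mL, a limit of the assay.

Compound 1 holds the only numerical result here. Compound 3 `C=C1[C@H](C)CCC[C@]1(C)CC/C(C)=C/CC1=C(O)C(=O)C=C(N[C@H](C(=O)O)C(C)C)C1=O` differs from it by 1-carboxy-2-methylpropyl in place of 1-carboxy-2-hydroxypropyl on an amine nitrogen. For the measured compounds named here, the sole measured step, an at least 2.1-fold higher number from compound 1 to compound 2 (0.33 log units; beyond the scatter), rests on the fact that compounds 1 and 2 differ only in the configuration as drawn and ends at the limit of > 10 ug/mL in this assay, at which 1 of the 2 values shown sits, so it concerns configuration alone and speaks only indirectly to a change of the whole side chain. Still, it shows this region to be sensitive. Compound 3 is therefore expected to give 9 ug/mL, spanning 3.5 ug/mL to 25 ug/mL, the estimated step being a 2.0-fold higher number from compound 1 to compound 3 (0.29 log units; within the scatter).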

Compound 3, half-maximal inhibitory concentration: 4.4 ug/mL
Compound 3: middle estimate off by 2.0-fold (0.31 log units), on the high side; the range from low to high includes it.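

In this assay the step of a 1.0-fold lower number from compound 1 to compound 3 (0.02 log units; within the scatter) comes with 1-carboxy-2-methylpropyl in place of 1-carboxy-2-hydroxypropyl on the amine nitrogen, so the value of compound 1 holds here without the hydroxyl of that side chain. The step of an at least 2.2-fold lower number from compound 2 to compound 3 (0.35 log units; beyond the scatter) comes with isopropyl in place of 1-hydroxyethyl on a saturated chain carbon bound to an amine nitrogen and a carbonyl carbon. Compound 2 gives > 10 ug/mL as a limit of the assay. Left open is how a longer chain, a primary amine or a phenyl ring on this carbon would read, and whether an amide could stand in for the carboxylic acid.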